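The source may hold more compounds than are shown below. What is called first, only, known or untested is meant among the compounds shown, and "the series" means these compounds.

For the measured compounds named here, compound 2 `O=C(C1=C(Nc2ccc(Br)cc2)C(=O)N(CCCn2ccnc2)C1c1ccc(Br)cc1)c1ccccc1` gives 23800 nM in a functional assay on SAOS-2 cells (Homo sapiens) for antiproliferative activity, read by MTT assay, with a stated time of 72 h (a lower number here means a stronger inhibitor, a higher number a weaker inhibitor), and the only other measured compound, compound 1 `CC(C)OC1=C(C(=O)c2ccccc2)C(c2ccc(Br)cc2)N(CCCn2ccnc2)C1=O`, gives 23000 nM, so the two numbers stand together; the step of a 1.0-fold higher number from compound 1 to compound 2 (0.01 log units; within the scatter). Compound 3 `O=C(C1=C(Nc2ccccc2Br)C(=O)N(CCCn2ccnc2)C1c1ccc(Br)cc1)c1ccccc1` differs from compound 2 by 2-bromophenyl in place of 4-bromophenyl on an amine nitrogen. Going by the values given here, only the step from compound 1 to compound 2 concerns the group on that same ring carbon, and exchanging the whole group there changed little, so no shift beyond the scatter is expected, and a 1.0-fold higher number from compound 2 to compound 3 (0.00 log units; within the scatter) is the estimated step. Compound 3 is therefore expected to give 24000 nM, in the range 12000 nM to 48000 nM.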

Compound 3, half-maximal inhibitory concentration: 19600 nM
Compound 3: middle estimate off by 1.2-fold (0.09 log units), on the high side; the range from low to high includes it.
By their numbers in this assay, from the lowest: compounds 3, 1 and 2 (each within the scatter of the next).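

With 2-bromophenyl in place of 4-bromophenyl on the amine nitrogen, this assay records a 1.2-fold lower number from compound 2 to compound 3 (0.08 log units; within the scatter) and so, in this pair, where the bromine sits on the phenyl ring makes no difference that can be told from scatter. Exchanging isopropoxy for (2-bromophenyl)amino on the double-bonded ring carbon gives a 1.2-fold lower number from compound 1 to compound 3 (0.07 log units; within the scatter) and thus also leaves the number unchanged within the scatter. No measurement at hand explains why these numbers stay together. Still open, going by these compounds, is whether an unsubstituted phenyl, or a methoxy or carboxylic acid in place of the bromine, would shift the number.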